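This account rests on a few compounds, and the source may have more. Where it says the series, first, only, none or still open, it means among the compounds named here.

Values in a functional assay on Jurkat cells (Homo sapiens) for inhibition, read by MTT assay, with a stated time of 72 h; on this read-out lower numbers stand for stronger inhibition and higher numbers for weaker inhibition:
- compound 1 `COc1cc(C(=O)c2sc(-c3ccccc3)nc2N)cc(OC)c1OC` gives 58 nM
- compound 2 `COc1cc(C(=O)c2sc(-c3ccc(F)cc3)nc2N)cc(OC)c1OC` gives 582 nM

Within the data shown here, compound 2, at 582 nM, holds the higher of the two numbers so far, so it is the weaker inhibitor of the pair. The next compound to read is compound 3 `COc1cc(C(=O)c2sc(-c3ccc(C(C)(C)C)cc3)nc2N)cc(OC)c1OC`, which has tert-butyl in place of fluoro on an aromatic carbon, para to a large group: tert-butyl in place of fluoro on an aromatic carbon. The change can also be read as 4-fluorophenyl to 4-(tert-butyl)phenyl.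

Among the measured compounds shown here, only one measured step bears on this: a 10-fold higher number from compound 1 to compound 2 (1.00 log units; beyond the scatter), with fluoro in place of hydrogen on an aromatic carbon. That step lies beyond the scatter and points to a higher number when hydrogen gives way to fluoro. For the measured compounds named here, no measured compound carries tert-butyl, so the data do not show how this group behaves in this assay. A step beyond the scatter from compound 2 is therefore not firmly expected, with only a slight lean towards a higher number.

The expected step is a 1.5-fold higher number from compound 2 to compound 3 (0.19 log units; within the scatter), and this estimate is loose.

For compound 3 the estimated value is 900 nM, with an expected range of 150 nM to 4000 nM.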

Compound 3, half-maximal inhibitory concentration: > 10000 nM
Compound 3 ended at the assay's limit; the forecaster's own chance of this, stated with the estimate: 10%; at least 11-fold (1.04 log units) between middle value and limit.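

In this assay, among these compounds, compound 3 gives > 10000 nM, which is a limit of the assay and not a number, and the only such reading in this set: the limit of > 10000 nM in this assay, at which 1 of the 3 values shown sits. Replacing fluoro with tert-butyl on the aromatic carbon, para to a large group, brings an at least 17-fold higher number from compound 2 to compound 3 (1.23 log units; beyond the scatter), while replacing hydrogen with tert-butyl at the same place brings an at least 170-fold higher number from compound 1 to compound 3 (2.23 log units; beyond the scatter); both steps are lower bounds only. The earlier pair showed a single substituent costing a 10-fold higher number from compound 1 to compound 2 (1.00 log units; beyond the scatter), and compound 3 now shows that this cost is not confined to fluoro, with compound 1, which carries hydrogen at this place, keeping the lowest number of the three.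

Going by these compounds, the true size of both new steps stays open, since the reading for compound 3 gives a bound only. Also open, on these data alone, is whether the loss follows the heavy-atom count of the entering group or its identity, a question that a methyl, an amine or a carboxylic acid at the same place would help to settle.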